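This account rests on a few compounds, and the source may have more. Where it says the series, first, only, none or still open, it means among the compounds named here.

For the measured compounds named here, compound 1 `CCCCCCCCCCCC(=O)OC[C@H](CSC[C@@H](N)C(=O)NC(C)(C)CO)OC(=O)CCCCCCCCCCC` is one of three compounds measured in an assay on HEK293 cells for agonist activity at Toll-like receptor 2 (Homo sapiens); a lower number here means that less compound is needed, a higher number that more compound is needed for the effect. Compound 1 gives 15500 nM. Compound 2 `CCCCCCCCCCCC(=O)OC[C@H](CSC[C@@H](N)C(=O)NCCCC(C)(C)CO)OC(=O)CCCCCCCCCCC` gives 30700 nM, and compound 3 `CCCCCCCCCCCC(=O)OC[C@H](CSC[C@@H](N)C(=O)NC(C)CCc1ccccc1)OC(=O)CCCCCCCCCCC` gives 160 nM. Among these three numbers compound 1 stands second highest: the step of a 2.0-fold higher number from compound 1 to compound 2 (0.30 log units; within the scatter) is within the scatter, so compounds 1 and 2 cannot be told apart, whereas compound 3 lies far lower.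

Compound 4 `CCCCCCCCCCCC(=O)OC[C@H](CSC[C@@H](N)C(=O)NC(C)CCC(C)C)OC(=O)CCCCCCCCCCC` has not yet been measured. It differs from compound 1 in one place: 1,4-dimethylpentyl in place of 1-(hydroxymethyl)-1-methylethyl on an amide-type nitrogen. The group carrying the hydroxymethyl on the amide-type nitrogen leaves, and a branched chain with no hydrogen-bond donor or acceptor enters.

Going by the values given here, no measured step makes exactly this change. Among the compounds with values here, the steps that bear on it are a 97-fold lower number from compound 1 to compound 3 (1.99 log units; beyond the scatter) and a 190-fold lower number from compound 2 to compound 3 (2.28 log units; beyond the scatter); both replace a group that carries a hydroxymethyl with 1-methyl-3-phenylpropyl, and both are large. Compound 4 likewise gives up the hydroxymethyl, but its 1,4-dimethylpentyl has no ring, so a large step downward is expected in this assay, though likely smaller than the step to compound 3. Compound 4 is therefore expected to give 1000 nM, within a range from 150 nM to 6000 nM. The estimated step is a 16-fold lower number from compound 1 to compound 4 (1.19 log units; beyond the scatter).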

Compound 4, half-maximal effective concentration: 190 nM
Compound 4: the middle estimate sits 5.3-fold (0.72 log units) above what was measured; the measured number falls inside the stated range.
By their numbers in this assay, from the lowest: compounds 3 and 4 (each within the scatter of the next); then compounds 1 and 2 (each within the scatter of the next).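

In this assay, a ring is not needed on the amide-type nitrogen: the change of phenyl to isopropyl gives a 1.2-fold higher number from compound 3 to compound 4 (0.07 log units; within the scatter) and leaves compounds 3 and 4 indistinguishable. The earlier large steps could have reflected either the arrival of the phenyl-bearing group or the loss of a hydroxymethyl-bearing group, but an 82-fold lower number from compound 1 to compound 4 (1.91 log units; beyond the scatter) and a 160-fold lower number from compound 2 to compound 4 (2.21 log units; beyond the scatter) are also large, and here the entering 1,4-dimethylpentyl has no ring and no hydrogen-bond donor or acceptor. Among these four compounds, the two lower numbers therefore go with the groups that carry no hydroxymethyl, while no measurement here explains this link.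

Each step away from compounds 1 and 2 alters the shape of the chain as well as removing the hydroxymethyl, so the contribution of the hydroxymethyl alone remains unresolved. Also open, from the compounds shown here alone, is how an amine or a carboxylic acid at the end of the 1,4-dimethylpentyl chain, or a shorter or longer all-carbon chain, would behave in this assay at this position.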